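A few compounds are considered here, and "the series" means these few. Any claim that something is new, unique, unknown or untested is made for them only; others in the source may bear on it.

Compound 3 `NC(=O)c1c(NC(=O)c2ccccc2Cl)sc2c1CCN(C(=S)Nc1ccccc1F)C2` gives 28700 nM in a functional assay on HeLa cells (Homo sapiens) for antiproliferative activity, with a stated time of 24 h; on this read-out higher numbers stand for weaker inhibition and lower numbers for stronger inhibition. Its number is close to those of its two neighbours: compound 1 `NC(=O)c1c(NC(=O)c2ccccc2Cl)sc2c1CCNC2` gives 45000 nM, and compound 2 `NC(=O)c1c(NC(=O)c2ccccc2Cl)sc2c1CCN(Cc1ccc(Cl)cc1Cl)C2` gives 21100 nM. Compound 4 `NC(=O)c1c(NC(=O)c2ccccc2Cl)sc2c1CCN(C(=S)Nc1ccc(C(F)(F)F)cc1)C2` differs from compound 3 by 4-(trifluoromethyl)phenyl in place of 2-fluorophenyl on an amide-type nitrogen. Going by the values given here, none of the measured steps touches this part of the molecule; all three change only the group on the amine nitrogen in the ring, and they were small: a 2.1-fold lower number from compound 1 to compound 2 (0.33 log units; beyond the scatter), a 1.6-fold lower number from compound 1 to compound 3 (0.20 log units; within the scatter) and a 1.4-fold higher number from compound 2 to compound 3 (0.13 log units; within the scatter). With no direct guide, the expectation is a step of little size, a 1.0-fold lower number from compound 3 to compound 4 (0.01 log units; within the scatter), in either direction. Compound 4 is therefore estimated at 28000 nM, with a range from 10000 nM to 80000 nM.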

Compound 4, half-maximal inhibitory concentration: > 50000 nM
Compound 4 ended at the assay's limit (the forecaster's own chance of this, stated with the estimate: 10%); at least 1.7-fold (0.25 log units) between middle value and limit.
By their numbers in this assay, from the lowest: compounds 2, 3 and 1 (each within the scatter of the next, the first and the last beyond it). At a limit, above all of these: compound 4.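

Going by these compounds alone, the first change at the amide-type nitrogen, 4-(trifluoromethyl)phenyl in place of 2-fluorophenyl, gives an at least 1.7-fold higher number from compound 3 to compound 4 (0.24 log units; that floor lies within the scatter), so this swap brought no stronger inhibition. Compound 4 stands at a limit of the assay, not at a number: the limit of > 50000 nM in this assay, at which 1 of the 4 values shown sits. As far as these compounds go, the full size of the step therefore stays unknown, and its floor alone does not establish a real loss.

Compounds 3 and 4 differ in both the substituent and its printed place on the phenyl ring, so these two effects cannot be separated. From the compounds shown here alone, how an amine or a carboxylic acid on that ring would behave also remains open.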